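Dropping an aromatic substituent from compound 1

This account rests on a few compounds, and the source may have more. Where it says the series, first, only, none or still open, it means among the compounds named here.

The set rests on a functional assay on MCF7 cells (Homo sapiens) for cytotoxicity, read by MTT assay, with a stated time of 48 h; a higher number here means a weaker inhibitor, a lower number a stronger inhibitor. Going by the values given here, compound 1, `[O-][S+](CCC(F)=C(F)F)c1ncc(-c2ccncc2)s1`, reaches no number there: in this assay compound 1 gives > 120000 nM, a limit of the assay rather than a measured value, and the limit of > 120000 nM in this assay, at which 1 of the 3 values shown sits, records that it is the one member of the three sitting at that limit. Two related compounds do give numbers. Compound 2, `[O-][S+](CCC(F)(Cl)C(F)(F)Cl)c1nc2ccccc2s1`, gives 17100 nM in this assay, and compound 3, `O=S(=O)(CCC(F)(Cl)C(F)(F)Cl)c1nc2ccccc2s1`, gives 10100 nM; these two values lie within the usual scatter of each other, so nothing can be read from their gap.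

Compound 4, `[O-][S+](CCC(F)=C(F)F)c1nccs1`, has not been measured. It differs from compound 1 by hydrogen in place of pyridin-4-yl on an aromatic carbon. Among the compounds with values here, no measured pair of compounds shows what this change does on its own, so the step can only be projected. Since compound 1 already stands at the limit, > 120000 nM, the removal of a ring is not expected to bring compound 4 into the measurable range. The step from compound 1 to compound 4 is expected to be a step that the limit leaves unreadable from compound 1 to compound 4, with the strong chance of a limit again. Compound 4 is accordingly estimated at 150000 nM, with a range from 60000 nM to 400000 nM.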

Compound 4, half-maximal inhibitory concentration: > 120000 nM
Compound 4: no number, only a limit; the forecaster's own chance of this, stated with the estimate: 80%; the middle value lies beyond the limit too.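

Compound 1 and compound 4 both stop at a limit of the assay, not at a number, so no step between them can be read: the limit of > 120000 nM in this assay, at which 2 of the 4 values shown sit.

The compounds shown leave open what hydrogen in place of pyridin-4-yl on an aromatic carbon does on its own in this assay.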